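From a Fluoro Group to a Fluorobenzyloxy Group

This account rests on a few compounds, and the source may have more. Where it says the series, first, only, none or still open, it means among the compounds named here.

For the measured compounds named here, compound 2 `Fc1cccc(-c2cn(C3CN4CCC3CC4)nn2)c1` stands at the higher of the two numbers measured so far: in an assay on HEK293 cells for displacement of a labelled ligand from Neuronal acetylcholine receptor; alpha3/beta4 (Homo sapiens), read by scintillation counting, with a stated time of 120 min (a higher number here means a weaker inhibitor, a lower number a stronger inhibitor), compound 2 gives 5.24 nM, whereas compound 1 `Fc1cccc(-c2cn([C@@H]3CN4CCC3CC4)nn2)c1` gives 2.25 nM. Going by the values given here, the only measured step, a 2.3-fold higher number from compound 1 to compound 2 (0.37 log units; beyond the scatter), rests on the fact that one of compounds 1 and 2 is drawn with a defined configuration and the other without, at the place where they differ and says nothing about the aromatic ring. Compound 3 `Fc1ccc(COc2cccc(-c3cn(C4CN5CCC4CC5)nn3)c2)cc1` differs from compound 2 by (4-fluorobenzyl)oxy in place of fluoro on an aromatic carbon. No measured step bears on such a change, so the size and direction of a 2.3-fold higher number from compound 2 to compound 3 (0.36 log units; beyond the scatter) is an estimate without precedent among these compounds. Compound 3 is expected to give 12 nM, within a wide range from 2 nM to 80 nM.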

Compound 3, inhibition constant: 13.9 nM
The estimate for compound 3 lay 1.2-fold (0.06 log units) below the measured number; low and high end bracket the measured number.
By their numbers in this assay, from the lowest: compound 1; then compound 2; then compound 3.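

Replacing fluoro with (4-fluorobenzyl)oxy, the first change to the aromatic ring among these compounds, gives a 2.7-fold higher number from compound 2 to compound 3 (0.42 log units; beyond the scatter) in this assay, a modest step. With 9 heavy atoms entering in place of 1, compound 3 still reads 13.9 nM, so this aromatic carbon tolerates a much larger group at a modest cost. Nothing measured here explains the step.

On these data alone, it remains open whether the oxygen, the added ring or its fluorine accounts for the step. As far as these compounds go, how a methoxy group or an amine would read at this carbon is also open.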